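Working notes: from compound 2 to compound 4

The compounds below may be only part of what the source reports. "The series", "measured", "known", "first", "only" and "open" are said of these compounds alone.

Values in a functional assay on SMMC-7721 cells (Homo sapiens) for antiproliferative activity, read by CCK-8 assay, with a stated time of 72 h; on this read-out higher numbers stand for weaker inhibition and lower numbers for stronger inhibition:
- compound 1 `CCc1ccc(SCc2ccc(/C=C/C(=O)Nc3ccccc3N)cc2)cc1`: "not determined" (no result reported)
- compound 2 `COc1ccc(SCc2ccc(C(=O)Nc3ccccc3N)cc2)cc1`: 2170 nM
- compound 3 `COc1ccc(SCc2ccc(C(=O)Nc3ccccc3N)cc2)cc1OC`: 3400 nM

Among the measured compounds shown here, only two numbers exist, and compound 2 does not separate from its single neighbour. Compound 4 `Nc1ccccc1NC(=O)c1ccc(CSc2ccc(F)cc2)cc1` carries fluoro in place of methoxy on an aromatic carbon, with fluoro in place of methoxy on an aromatic carbon, para to a large group. For the measured compounds named here, the one measured step adds a methoxy and so bears only indirectly: a 1.6-fold higher number from compound 2 to compound 3 (0.20 log units; within the scatter). Going by the values given here, no measured step exchanges methoxy for fluoro. No step beyond the scatter is therefore expected in this assay, and no direction can be assigned. The expected change is a 1.2-fold higher number from compound 2 to compound 4 (0.06 log units; within the scatter). For compound 4 the estimated value is 2500 nM, with an expected range of 1000 nM to 6000 nM.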

Compound 4, half-maximal inhibitory concentration: 5770 nM
Compound 4: middle estimate off by 2.3-fold (0.36 log units), on the low side; measured number inside the range.
By their numbers in this assay, from the lowest: compounds 2, 3 and 4 (each within the scatter of the next, the first and the last beyond it).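

In this assay, among the compounds shown here, the change from 4-methoxyphenyl to 4-fluorophenyl gives a 2.7-fold higher number from compound 2 to compound 4 (0.42 log units; beyond the scatter) as the first step beyond the scatter, so the group at this position can shift the read-out. The added methoxy gave only a 1.6-fold higher number from compound 2 to compound 3 (0.20 log units; within the scatter) and did not show this. No measurement at hand offers an explanation for the step.

From the compounds shown here alone, with only methoxy and fluoro to compare at this position, it remains open how an amine, a carboxylic acid or a hydroxyl group there would read in this assay on the same core.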